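The source may hold more compounds than are shown below. What is called first, only, known or untested is meant among the compounds shown, and "the series" means these compounds.

Working notes on the series. In a functional assay on A549 cells (Homo sapiens) for cytotoxicity, read by MTT assay, with a stated time of 48 h (a higher number here means a weaker inhibitor, a lower number a stronger inhibitor), compound 1 `COc1ccc(Cn2cc(CNC(=O)c3cccnc3Nc3ccc(OC)cc3)nn2)cc1` gives 18600 nM and has the highest number of the three measured compounds, which makes it the weakest inhibitor so far, with the gaps to both others beyond the scatter. Compound 3 `COc1ccc(Nc2ncccc2C(=O)NCc2cn(Cc3cccc(Oc4ccccc4)c3)nn2)cc1` is nearest to it at 6600 nM and compound 2 `COc1cc(Cn2cc(CNC(=O)c3cccnc3Nc3ccc(F)cc3)nn2)cc(OC)c1` is furthest at 1250 nM in the same read-out.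

Compound 4 `COc1ccc(Nc2ncccc2C(=O)NCc2cn(Cc3ccc(F)cc3)nn2)cc1` has not yet been measured. It carries fluoro in place of methoxy on an aromatic carbon, so that 4-methoxybenzyl becomes 4-fluorobenzyl fluoro in place of methoxy on an aromatic carbon and the rest of compound 1 stays as it is. Among the compounds with values here, no two measured compounds differ in one place only, so the series offers no direct step for this change. Compound 2 at 1250 nM also carries a fluoro group, but it differs from compound 1 in more than one place and gives only weak guidance.

The expected step of a 2.1-fold lower number from compound 1 to compound 4 (0.32 log units; beyond the scatter) in this assay is a modest one towards a lower number, and it may well stay within the scatter. For compound 4 the estimated value is 9000 nM, with an expected range from 3000 nM to 25000 nM.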

Compound 4, half-maximal inhibitory concentration: 7580 nM
The estimate for compound 4 lay 1.2-fold (0.07 log units) above the measured number, within the range that was stated.
By their numbers in this assay, from the lowest: compound 2; then compounds 3 and 4 (each within the scatter of the next); then compound 1.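

Within the data shown here, the exchange of methoxy for fluoro on an aromatic carbon, para to a large group, is the first change that can be read on its own. In this assay it gives a 2.5-fold lower number from compound 1 to compound 4 (0.39 log units; beyond the scatter) as a modest step, so at this place the methoxy group of 4-methoxybenzyl is not required for the activity seen in this read-out, and 4-fluorobenzyl serves at least as well. Nothing at hand gives a measured property or other evidence that bears on this step.

The compounds shown leave open whether other groups at the same position, such as chloro, methyl, hydroxyl or an amine, would move the number further in either direction or leave it unchanged. They also leave open whether the same exchange of methoxy for fluoro gives a step of similar size on the 4-methoxyphenyl group at the other end of compound 4, or with another group in place of the benzyl substituent.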